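The compounds below may be only part of what the source reports. "The series", "measured", "known", "first", "only" and "open" are said of these compounds alone.

Compound 1 `CC(C)c1cc(C(=O)N(C)c2ccc(NC(=O)CCCCCCCC(=O)NO)cc2)c(O)cc1O`: 1060 nM
Compound 2 `CCN(C(=O)c1cc(C(C)C)c(O)cc1O)c1cccc(NC(=O)CCCCCCC(=O)NO)c1`: 1120 nM

Both compounds were tested in a functional assay on HCT-116 cells (Homo sapiens) for inhibition, read by sulforhodamine B assay, with a stated time of 48 h; a lower number here means a stronger inhibitor of growth, a higher number a weaker inhibitor of growth. Compound 1 gives 1060 nM and compound 2 gives 1120 nM. These two values lie within the scatter of each other, so neither compound can be ranked above the other.

Compound 3 `CC(C)c1cc(C(=O)N(C)c2ccc(NC(=O)CCCCCC(=O)NO)cc2)c(O)cc1O` has not yet been measured. It keeps the core of compound 1 but carries a shorter chain, with hydroxycarbamoyl in place of 2-(hydroxycarbamoyl)ethyl on a saturated chain carbon, five bonds along the chain from a carbonyl carbon.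

Among the compounds with values here, no measured pair isolates this change, so the expectation is loose: no clear step beyond the scatter, in either direction. The estimated step, a 1.2-fold lower number from compound 1 to compound 3 (0.07 log units; within the scatter), is therefore small. For compound 3 the expected value is 900 nM, with an estimated range of 350 nM to 2500 nM.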

Compound 3, concentration for 50% growth inhibition: 3780 nM
Compound 3: the middle estimate sits 4.2-fold (0.62 log units) below what was measured, outside the stated range (above it).
By their numbers in this assay, from the lowest: compounds 1 and 2 (each within the scatter of the next); then compound 3.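

Within the data shown here, this is the first pair that isolates a single change. With the rest of compound 1 kept, hydroxycarbamoyl in place of 2-(hydroxycarbamoyl)ethyl on a saturated chain carbon, five bonds along the chain from a carbonyl carbon, gives a 3.6-fold higher number from compound 1 to compound 3 (0.55 log units; beyond the scatter) in this assay, a modest step beyond the scatter. Chain length at this place therefore matters in these cells, with the shorter chain of compound 3 giving the weaker inhibitor of growth, but nothing measured here explains the rise.

Among these compounds, only two chain lengths can be compared on this core, so it remains open whether a longer chain than that of compound 1 would lower the number or raise it. Also open, as far as these compounds go, is how a carboxylic acid would behave in place of the hydroxycarbamoyl end.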